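Thiophen-2-yl to phenyl swap on the compound 1 core

This account rests on a few compounds, and the source may have more. Where it says the series, first, only, none or still open, it means among the compounds named here.

Measured so far:
compound 1 `Cn1cccc1-c1cc(-c2cccs2)[nH]c(=O)c1C#N`: > 100000 nM, a limit of the assay, not a number
compound 2 `COc1ccc(-c2cc(-c3cccn3C)c(C#N)c(N)n2)cc1OC`: 40700 nM

In a functional assay on OVCAR-4 cells (Homo sapiens) for inhibition, read by sulforhodamine B assay, with a stated time of 48 h (a higher number here means a weaker inhibitor of growth, a lower number a stronger inhibitor of growth), compound 1 gives > 100000 nM, which is a limit of the assay rather than a measured number. Compound 1 therefore stands at the limit of > 100000 nM in this assay, at which 1 of the 2 values shown sits, with no numerical position within the series. For the measured compounds named here, compound 2 differs from compound 1 in more than one place, so no single step is drawn between the two; its value in this assay is simply a number while that of compound 1 is not.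

Compound 3 `Cn1cccc1-c1cc(-c2ccccc2)[nH]c(=O)c1C#N` differs from compound 1 only by phenyl in place of thiophen-2-yl on an aromatic carbon. Going by the values given here, no measured pair shows this change, so its size is unknown. With compound 1 sitting at the limit of > 100000 nM in this assay, at which 1 of the 2 values shown sits, no step beyond the usual scatter is expected, and the expected step is a number no higher from compound 1 to compound 3 (the limit leaves the size open). Compound 3 is accordingly estimated at 100000 nM in this assay, with a range from 30000 nM to 300000 nM, and most likely it too will be reported only as a limit.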

Compound 3, concentration for 50% growth inhibition: > 100000 nM
Compound 3 gave a limit, no number; the forecaster's own chance of this, stated with the estimate: 70%; the middle value lies on the limit itself.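

No step can be read from compound 1 to compound 3 in this assay, because both results are limits of the assay and not numbers: the limit of > 100000 nM in this assay, at which 2 of the 3 values shown sit.

The compounds shown leave open whether phenyl in place of thiophen-2-yl on an aromatic carbon changes growth inhibition at all, and by how much.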